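Working notes: halophenyl exchange and cytotoxicity

This account rests on a few compounds, and the source may have more. Where it says the series, first, only, none or still open, it means among the compounds named here.

Measured so far:
compound 1 `C=CCn1c(=O)/c(=C\c2cccc(Cl)c2)[nH]c(=O)/c1=C\c1ccccc1OC`: 4500 nM
compound 2 `C=CCn1c(=O)/c(=C\c2cccc(Br)c2)[nH]c(=O)/c1=C\c1cccc(Br)c1`: "not active" (no number reported)

Among the compounds with values here, in a functional assay on HL-60 cells (Homo sapiens) for cytotoxicity, read by CCK-8 assay, with a stated time of 72 h (on this read-out lower numbers stand for stronger inhibition and higher numbers for weaker inhibition), compound 1 gives 4500 nM, the sole numerical value among the measured compounds; compound 2 was reported as "not active" (no number reported) without a number, so it supplies no comparison. Compound 3 `C=CCn1c(=O)/c(=C\c2ccccc2F)[nH]c(=O)/c1=C\c1ccccc1OC` differs from compound 1 by 2-fluorophenyl in place of 3-chlorophenyl on a double-bonded chain carbon bound to an aromatic carbon. Within the data shown here, no step between measured compounds exists, so the expected change rests on the structural exchange alone; a small shift in this assay, if any, is expected, not beyond the usual scatter, leaning slightly weaker. Compound 3 is expected at 6000 nM, within 2500 nM to 15000 nM. That estimate means a step of a 1.3-fold higher number from compound 1 to compound 3 (0.12 log units; within the scatter).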

Compound 3, half-maximal inhibitory concentration: 18500 nM
For compound 3 the middle estimate is 3.1-fold (0.49 log units) below the measured one; measured number above the stated range.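

In this assay the exchange to 2-fluorophenyl from 3-chlorophenyl on a double-bonded chain carbon bound to an aromatic carbon gives a 4.1-fold higher number from compound 1 to compound 3 (0.61 log units; beyond the scatter) and so shows that the series responds to a change at this place. The two groups match in heavy-atom count, donors, acceptors and charge, yet the step lies beyond the scatter. Nothing measured here accounts for the step.

The halogen and its place on the ring change together, so their contributions cannot be separated. On these data alone, a 3-fluorophenyl group would separate them, and how an amine or a carboxylic acid on this ring would fare remains open.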